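Dropping the hydroxymethyl from compound 3

The compounds below may be only part of what the source reports. "The series", "measured", "known", "first", "only" and "open" are said of these compounds alone.

In a functional assay on HeLa cells (Homo sapiens) for inhibition (on this read-out lower numbers stand for stronger inhibition and higher numbers for weaker inhibition), compound 3 `CCCCCCCCCCCCCCCCCCOC[C@H](COC(=O)O[C@@H]1[C@H](O)[C@H](CO)[C@@H](O)[C@H](O)[C@@H]1O)OC` reads 2500 nM, the higher of the two true numbers in the series. Compound 2 `CCCCCCCCCCCCCCCCCCOC[C@H](COP(=O)(O)O[C@@H]1[C@H](O)[C@H](CO)[C@@H](O)[C@H](O)[C@@H]1O)OC` reads lower at 1000 nM, a gap beyond the scatter. Compound 1 `CCCCCCCCCCCCCCCCCCOC[C@H](COC(=O)O[C@@H]1[C@H](O)[C@@H](CO)[C@@H](O)[C@H](O)[C@@H]1O)OC` gives > 20000 nM, which is a limit of the assay and not a number.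

Compound 4 `CCCCCCCCCCCCCCCCCCOC[C@H](COC(=O)O[C@H]1[C@@H](O)[C@@H](O)[C@H](O)C[C@H]1O)OC` carries hydrogen in place of hydroxymethyl on a saturated ring carbon.

Among the measured compounds shown here, one measured step bears on this change. It is an at least 8.0-fold lower number from compound 1 to compound 3 (0.90 log units; beyond the scatter), and it comes with the fact that compounds 1 and 3 differ only in the configuration as drawn and with the limit of > 20000 nM in this assay, at which 1 of the 3 values shown sits. The stereocentre concerned is the ring carbon holding the hydroxymethyl, so this assay responds to how that carbon is drawn. On the strength of that step from compound 1 to compound 3, a rise beyond the scatter is expected on losing the group, probably smaller than that step, and a limit reading remains possible.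

The expected change is a 2.8-fold higher number from compound 3 to compound 4 (0.45 log units; beyond the scatter). For compound 4 the estimated value is 7000 nM, with an expected range of 2500 nM to 20000 nM.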

Compound 4, half-maximal inhibitory concentration: 30000 nM
Estimate against measurement, compound 4: 4.3-fold (0.63 log units) below; measured number outside the range, above it.
By their numbers in this assay, from the lowest: compound 2; then compound 3; then compound 4.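

In this assay, removing the hydroxymethyl from this saturated ring carbon gives a 12-fold higher number from compound 3 to compound 4 (1.08 log units; beyond the scatter), a large change. The earlier compounds shown here showed only that the way this carbon is drawn matters while the group stays in place: the fact that compounds 1 and 3 differ only in the configuration as drawn Compound 1 gives > 20000 nM, which is a limit and not a number, and the step from it to compound 4 cannot be read.

On these data alone, it remains open whether this loss follows from the missing oxygen or from the missing carbon, a question that a methyl, an aminomethyl or a carboxylic acid on the same ring carbon would help to address. As far as these compounds go, it also remains open whether hydrogen in place of hydroxymethyl would have a similar effect on compound 2, which carries the phosphate link.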